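A few compounds are considered here, and "the series" means these few. Any claim that something is new, unique, unknown or untested is made for them only; others in the source may bear on it.

In a functional assay on MGC-803 cells (Homo sapiens) for inhibition, read by sulforhodamine B assay (a higher number here means a weaker inhibitor, a lower number a stronger inhibitor), compound 1 `CCCc1ccc(NC2=CC(=O)c3nc4n(c3C2=O)[C@H]2OC[C@@H](O)[C@H]2OC4)cc1` gives 1560 nM. Compound 2 `O=C1C=C(NC2CCCCC2)C(=O)c2c1nc1n2[C@H]2OC[C@@H](O)[C@H]2OC1` carries cyclohexyl in place of 4-propylphenyl on an amine nitrogen. In this assay compound 2 reaches only > 8000 nM, which is a limit of the assay and not a number. The step reads an at least 5.1-fold higher number from compound 1 to compound 2 (0.70 log units; beyond the scatter), which rests on (the limit of > 8000 nM in this assay, at which 1 of the 3 values shown sits). Compound 3 `CCCc1ccc(NC2=CC(=O)c3c(nc4n3[C@H]3OC[C@@H](O)[C@H]3OC4)C2=O)cc1` is built from the same atoms as compound 1, joined differently; the difference between the two cores is not broken down here. In this assay compound 3 gives 1920 nM, and its two measured neighbours stand close to each other. Compound 4 `O=C1C(NC2CCCCC2)=CC(=O)c2c1nc1n2[C@H]2OC[C@@H](O)[C@H]2OC1` has not yet been measured in this assay; it carries cyclohexyl in place of 4-propylphenyl on an amine nitrogen, the same change that turns compound 1 into compound 2. The step from compound 3 to compound 4 is expected to be about a 6.3-fold higher number from compound 3 to compound 4 (0.80 log units; beyond the scatter), an expectation resting on the step of an at least 5.1-fold higher number from compound 1 to compound 2 (0.70 log units; beyond the scatter) and on (the limit of > 8000 nM in this assay, at which 1 of the 3 values shown sits). Compound 4 is therefore estimated at 12000 nM, with a likely range from 5000 nM to 30000 nM, and it may well be reported only as a limit.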

Compound 4, half-maximal inhibitory concentration: > 8000 nM
Compound 4: only a limit was reported (the forecaster's own chance of this, stated with the estimate: 70%); the middle value lies beyond the limit too.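

Carrying cyclohexyl in place of 4-propylphenyl on an amine nitrogen over to the second core gives an at least 4.1-fold higher number from compound 3 to compound 4 (0.61 log units; beyond the scatter), so in this assay the change moves the number the same way on both cores, towards weaker inhibition: the same change on two cores in this assay, an at least 5.1-fold higher number (0.70 log units; beyond the scatter) from compound 1 to compound 2 and an at least 4.1-fold higher number (0.61 log units; beyond the scatter) from compound 3 to compound 4; the limit leaves it open whether they differ

What carries over is therefore the direction of the change, and its size on either core stays unknown, because each step ends at a limit of the assay rather than a number: the limit of > 8000 nM in this assay, at which 2 of the 4 values shown sit.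

Two cores are also all that is shown, so this says nothing about how the change would behave on any other core.

The compounds shown leave open whether the loss follows from the missing aromatic ring or the missing propyl chain, since the two groups differ in both, and a plain phenyl or a 4-propylcyclohexyl group would separate these. They also leave open how a longer chain on the phenyl ring, or a benzyl group on the amine nitrogen, would read in this assay.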